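Moving the chlorine once more on the sulfonyl-linked ring

This account rests on a few compounds, and the source may have more. Where it says the series, first, only, none or still open, it means among the compounds named here.

Compound 3 `O=S(=O)(c1cccc(Cl)c1)c1cn(C2CCCNC2)c2ncccc12` carries a 3-chlorophenyl on its sulfonyl sulfur, and in an assay on HeLa cells for displacement of a labelled ligand from 5-hydroxytryptamine receptor 6 (Homo sapiens) (on this read-out higher numbers stand for weaker inhibition and lower numbers for stronger inhibition), compound 3 gives 1.3 nM. Among the measured compounds shown here, of the three compounds measured so far, that is the lowest number. The unsubstituted parent, compound 1 `O=S(=O)(c1ccccc1)c1cn(C2CCCNC2)c2ncccc12`, gives 4.9 nM in this assay, and compound 2 `O=S(=O)(c1ccccc1Cl)c1cn(C2CCCNC2)c2ncccc12`, which bears a 2-chlorophenyl, gives 3.7 nM. The step of a 1.3-fold lower number from compound 1 to compound 2 (0.12 log units; within the scatter) is too small to count, whereas a 3.8-fold lower number from compound 1 to compound 3 (0.58 log units; beyond the scatter) and a 2.8-fold lower number from compound 2 to compound 3 (0.45 log units; beyond the scatter) are both modest but real.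

Compound 4 `O=S(=O)(c1ccc(Cl)cc1)c1cn(C2CCCNC2)c2ncccc12` is the remaining member of this small series: 4-chlorophenyl in place of 3-chlorophenyl on a sulfonyl sulfur. The step that bears most directly on it is a 2.8-fold lower number from compound 2 to compound 3 (0.45 log units; beyond the scatter). That step also exchanges one chlorophenyl for another on the same sulfur, and it shows that where the chlorine sits can shift this assay by a modest amount in either direction. Since the single chlorine has already given one quiet step and one helpful step, he expects compound 4 to land close to compound 3, with a slight lean toward a higher number, estimating a step of a 1.9-fold higher number from compound 3 to compound 4 (0.28 log units; within the scatter). In this assay compound 4 is therefore expected to give about 2.5 nM, within 0.8 nM to 8 nM.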

Compound 4, inhibition constant: 7.6 nM
Beside the measured number, compound 4's estimate is 3.0-fold (0.48 log units) below it; the measured number falls inside the stated range.
By their numbers in this assay, from the lowest: compound 3; then compounds 2, 1 and 4 (each within the scatter of the next, the first and the last beyond it).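

Moving the chlorine without changing any atom count is enough to separate these compounds: in this assay the exchange of 3-chlorophenyl for 4-chlorophenyl on the sulfonyl sulfur gives a 5.8-fold higher number from compound 3 to compound 4 (0.77 log units; beyond the scatter) and so undoes the gain that the 3-chlorophenyl had shown over the unsubstituted phenyl. The 4-chlorophenyl also stands apart from the 2-chlorophenyl, with a 2.1-fold higher number from compound 2 to compound 4 (0.31 log units; beyond the scatter) as the step, so the three placements of the chlorine do not read as equivalent, although the separation here is modest. Against the parent the step is a 1.6-fold higher number from compound 1 to compound 4 (0.19 log units; within the scatter) and the 4-chlorophenyl cannot be told from the plain phenyl, which leaves compound 3 as the only one of the three chlorinated compounds that departs from compound 1 beyond the scatter, so the gain belongs to that one placement and not to chlorine as such.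

The compounds shown leave open whether a fluoro, a methoxy or a nitrile in place of the chlorine would follow the same order across the ring. Nothing in hand accounts for why the placement of the chlorine matters in this way.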